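The source may report more compounds than this note shows. Statements on the series, on what has been measured and on what is new or still open speak of the compounds shown alone.

Three compounds have been measured in a functional assay on SR cells (Homo sapiens) for inhibition, read by sulforhodamine B assay, with a stated time of 48 h, tested at 10 uM; a higher number here means more inhibition of growth at the concentration tested, a lower number less inhibition of growth:

compound 1, `COc1cc(-c2nc(N)n(CC(=O)Nc3ccc(/C(C)=N\O)cc3)n2)cc(OC)c1OC`, gives 17%;
compound 2, `C/C(=N/O)c1ccc(NC(=O)Cn2nc(-c3ccccc3)nc2N)cc1`, gives 5.58%;
compound 3, `c1ccc(-c2nc3sc(-c4ccccc4)cn3n2)cc1`, gives 9%.

Compound 2 stands lowest of the three numbers. Its nearest neighbour is compound 3, which sits within the usual scatter of it, so the two cannot be told apart. Compound 1 lies furthest away, beyond the scatter, with the higher growth inhibition of the three. All three values are modest at the concentration used.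

The next compound, compound 4, `C/C(=N/O)c1ccc(NC(=O)Cn2nc(C(F)(F)F)nc2N)cc1`, differs from compound 2 in one place: trifluoromethyl in place of phenyl on an aromatic carbon. Within the data shown here, no pair of measured compounds differing in a single place has been recorded, so there is no measured step to lean on; the change swaps a ring for a small group without adding donors, acceptors or charge. Because compound 2 already gives only 5.58% in this assay, there is little room for a drop, and nothing in the shown compounds points to a large rise.

Compound 4 is therefore estimated at 8% in this assay, expected to lie between 0% and 20%. The expected step, a number 2.4 percentage points higher from compound 2 to compound 4 (within the scatter), is estimated to stay within the scatter in either direction.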

Compound 4, percent growth inhibition at one concentration: 16%
For compound 4 the middle estimate is 8 percentage points below the measured one; the measured number falls inside the stated range.
By their numbers in this assay, from the lowest: compounds 2, 3, 4 and 1 (each within the scatter of the next, the first and the last beyond it).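

In this assay, the step from phenyl to trifluoromethyl on this aromatic carbon of the five-membered ring gives a number 10.4 percentage points higher from compound 2 to compound 4 (beyond the scatter), the first single change measured in this series. At this place, a six-membered aromatic ring is therefore not required for the growth inhibition seen, and a group with fewer heavy atoms and no ring gives the higher reading, although the step is still modest. No measurement shown here explains this step.

The compounds shown leave open whether the rise goes with losing the phenyl ring or with gaining the fluorine atoms. A plain methyl group or an amine on the same carbon would help separate these two readings, and a longer chain would show how much size this position accepts.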